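Relocating the Trifluoromethyl Group: Compound 3 Expected Level with Compound 2

This account rests on a few compounds, and the source may have more. Where it says the series, first, only, none or still open, it means among the compounds named here.

Compound 1 `COc1ccc(N2CCN(Cc3csc(N)c3C(=O)c3ccc(Cl)cc3)CC2)cc1` and compound 2 `Nc1scc(CN2CCN(c3cccc(C(F)(F)F)c3)CC2)c1C(=O)c1ccc(Cl)cc1` share one core and differ only in the aryl group on an amine nitrogen in a ring. In an assay on CHO cells for displacement of a labelled ligand from adenosine receptor A1 (Homo sapiens), read by scintillation counting, with a stated time of 120 min, tested at 10 uM (on this read-out higher numbers stand for more inhibition at the one concentration tested (going by the name of the read-out) and lower numbers for less inhibition), compound 1 gives 0%, and in this assay compound 2 gives 0%. The step of no change at the digits printed from compound 1 to compound 2 (within the scatter) shows that exchanging that aryl group left the read-out unchanged. Compound 2 therefore stands level with compound 1 at the digits shown in this assay.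

Compound 3 `Nc1scc(CN2CCN(c3ccccc3C(F)(F)F)CC2)c1C(=O)c1ccc(Cl)cc1` is the next member of the set. Its difference from compound 2 is 2-(trifluoromethyl)phenyl in place of 3-(trifluoromethyl)phenyl on an amine nitrogen in a ring. Within the data shown here, the only measured step that bears on this change is no change at the digits printed from compound 1 to compound 2 (within the scatter), which stayed within the scatter even though it swapped one aryl group for a quite different one. The change to compound 3 keeps the same atoms and the same core, so no step beyond the scatter is expected in this assay, and the estimated step is no change at the digits printed from compound 2 to compound 3 (within the scatter). Compound 3 is thus estimated to give 0% in this assay, within -10% to 15%.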

Compound 3, a percentage reported as inhibition, at one concentration (the size of the read-out at that concentration, not a potency): 0%
Estimate against measurement, compound 3: no gap at the digits printed; the range from low to high includes it.
By their numbers in this assay, from the lowest: compounds 1, 2 and 3 (each within the scatter of the next).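

In this assay, exchanging 3-(trifluoromethyl)phenyl for 2-(trifluoromethyl)phenyl on the amine nitrogen in the ring gives no change at the digits printed from compound 2 to compound 3 (within the scatter), the first sign that the same atoms, joined differently, leave this read-out unmoved. Against the 4-methoxyphenyl group, the new aryl group gives no change at the digits printed from compound 1 to compound 3 (within the scatter), so all three aryl groups shown on this nitrogen read alike, with no inhibition recorded at the one concentration tested. Nothing measured here bears on why these compounds read alike.

With all three compounds at the same reading, the set cannot tell whether the aryl group on this nitrogen has any bearing on displacement of the labelled ligand, or whether any change at this place would register in this assay. It also leaves open what a carboxylic acid or an amine on that phenyl ring would do, and what would follow if the aryl group gave way to a plain phenyl or a longer alkyl chain.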